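Methyl in place of fluoro on the aryl ring of compound 1

The source may report more compounds than this note shows. Statements on the series, on what has been measured and on what is new or still open speak of the compounds shown alone.

Compound 1 `CC(C)(C)n1ncc(OCc2nnc(-c3cccc(F)c3)o2)c(Cl)c1=O` stands lowest of the three measured compounds in a physicochemical assay for lipophilicity (on this read-out lower numbers stand for lower lipophilicity and higher numbers for higher lipophilicity), where compound 1 gives 2.69. Compound 3 `CC(C)(C)n1ncc(OCc2nnc(-c3ccccc3F)o2)c(Cl)c1=O` gives 2.89 and sits nearest, with a number 0.20 log units higher from compound 1 to compound 3 (within the scatter). Compound 2 `CC(C)(C)n1ncc(OCc2nnc(-c3ccc(Cl)cc3)o2)c(Cl)c1=O` gives 3.09 and lies furthest away, with a number 0.40 log units higher from compound 1 to compound 2 (beyond the scatter). Compound 4 `Cc1cccc(-c2nnc(COc3cnn(C(C)(C)C)c(=O)c3Cl)o2)c1` has not yet been measured; it differs from compound 1 by methyl in place of fluoro on an aromatic carbon. Within the data shown here, no measured step exchanges a fluoro for a methyl, so no step bears on this change directly. Among the measured compounds shown here, the only step beyond the scatter, a number 0.40 log units higher from compound 1 to compound 2 (beyond the scatter), trades one halogen for another, while a number 0.20 log units lower from compound 2 to compound 3 (within the scatter) stays within the scatter. On this basis a modest rise is expected, of about the size seen between compound 1 and compound 2. Compound 4 is therefore estimated at 3.05, with a range from 2.8 to 3.3. The expected step is a number 0.36 log units higher from compound 1 to compound 4 (beyond the scatter).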

Compound 4, partition coefficient: 3.02
Compound 4: middle estimate off by 0.03 log units, on the high side; low and high end bracket the measured number.
By their numbers in this assay, from the lowest: compounds 1, 3, 4 and 2 (each within the scatter of the next, the first and the last beyond it).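

In this assay, among these compounds, exchanging fluoro for methyl gives a number 0.33 log units higher from compound 1 to compound 4 (beyond the scatter) and, unlike the earlier steps, changes only the group while keeping its place on the ring. This shows that the read-out at this position responds to a halogen-free substituent, though the size of the step is modest. Compound 4 does not separate from the other two aryl variants, with a number 0.13 log units higher from compound 3 to compound 4 (within the scatter) and a number 0.07 log units lower from compound 2 to compound 4 (within the scatter), so 3-methylphenyl stands apart from neither 2-fluorophenyl nor 4-chlorophenyl. Nothing measured alongside these numbers accounts for the step.

On these data alone, it remains open whether an amine, a methoxy group or a carboxylic acid at this place would raise or lower the number. As far as these compounds go, it is also open whether 2-methylphenyl or 4-methylphenyl would stand with compound 4.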